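Swapping the aryl end of a dihydropyridine-style chain

This account rests on a few compounds, and the source may have more. Where it says the series, first, only, none or still open, it means among the compounds named here.

Of the compounds shown here, three have been measured in a functional assay (aorta) with Oryctolagus cuniculus as the target; a higher number here means weaker binding, a lower number tighter binding. Compound 1 `COc1cc(C(C)=O)ccc1OCCCN1CCC(CC(c2ccc(F)cc2)c2ccc(F)cc2)CC1` gives 3.16 nM, and compound 2 `COc1cc(C(C)=O)ccc1OCCCN1CCC(=C(c2ccc(F)cc2)c2ccc(F)cc2)CC1` gives 3.98 nM. Compound 3 `CC(=O)c1ccc(OCCCN2CCC(C(c3ccc(F)cc3)c3ccc(F)cc3)CC2)cc1` gives 2.51 nM, the lowest of the three numbers shown, although its gaps to compound 1 and to compound 2 both fall within the usual scatter, so no ordering among them can be claimed.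

Compound 4 `COc1ccccc1OCCCN1CCC(C(c2ccc(F)cc2)c2ccc(F)cc2)CC1` has not yet been measured. It differs from compound 3 in one place: 2-methoxyphenyl in place of 4-acetylphenyl on an oxygen on a saturated carbon.

For the measured compounds named here, no measured pair shows this exact change, so the expectation rests on the three values alone, which all sit close together whether or not a methoxy group or an acetyl group is present. The step is therefore expected to be small, a 1.6-fold higher number from compound 3 to compound 4 (0.20 log units; within the scatter), in either direction or none beyond the scatter. On that basis compound 4 is estimated to give about 4 nM in this assay, with a plausible range from 1.5 nM to 12 nM.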

Compound 4, dissociation constant: 2.51 nM
For compound 4 the middle estimate is 1.6-fold (0.20 log units) above the measured one; the range from low to high includes it.
By their numbers in this assay, from the lowest: compounds 3, 4, 1 and 2 (each within the scatter of the next).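

In this assay, for the compounds shown here, placing 2-methoxyphenyl in place of 4-acetylphenyl on the oxygen gives no change at the digits printed from compound 3 to compound 4 (within the scatter), the first direct reading of a change at this position. The two aryl groups differ in their substituent and in where it sits, yet this one swap leaves the number unmoved, so this position accepts at least this exchange without a step beyond the scatter. No separate measurement is available to explain this result.

A plain phenyl group, carrying neither methoxy nor acetyl, would show whether either substituent contributes anything at all. A carboxylic acid or an amine on the same ring would test whether this tolerance extends to groups of a very different kind, which this single pair cannot say.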